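A few compounds are considered here, and "the series" means these few. Any claim that something is new, unique, unknown or untested is made for them only; others in the source may bear on it.

Within the data shown here, compound 2 `Cc1ccccc1-c1ccccc1OC(C)C1=NCCN1` stands at the lower end of the two numbers measured so far: in an assay on CHO cells for displacement of a labelled ligand from Alpha-2C adrenergic receptor (Homo sapiens) (on this read-out lower numbers stand for stronger inhibition and higher numbers for weaker inhibition), compound 2 gives 234 nM, whereas compound 1 `CC(Oc1ccccc1-c1ccccc1O)C1=NCCN1` gives 1620 nM in this assay. Among the measured compounds shown here, the only step known between measured compounds is a 6.9-fold lower number from compound 1 to compound 2 (0.84 log units; beyond the scatter), which shows that what is attached at this point of the shared core moves the number by a modest but real margin.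

Compound 3 `CC(Oc1ccccc1-c1cccs1)C1=NCCN1` carries a different change at the same point: thiophen-2-yl in place of 2-methylphenyl on an aromatic carbon, placed ortho to a group of 8 heavy atoms. For the measured compounds named here, no measured step covers the swap of the whole aromatic group, so the step from compound 1 to compound 2 bears on it only in showing that this position is sensitive. Because a 6.9-fold lower number from compound 1 to compound 2 (0.84 log units; beyond the scatter) ran from a compound bearing hydroxy to one bearing methyl, and compound 3 loses the methyl together with the six-membered ring, a modest move back toward a higher number is expected, though the direction is uncertain. For compound 3 the expected step is a 2.1-fold higher number from compound 2 to compound 3 (0.33 log units; beyond the scatter), giving an estimate of 500 nM with a range from 150 nM to 1800 nM.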

Compound 3, inhibition constant: 72.4 nM
For compound 3 the middle estimate is 6.9-fold (0.84 log units) above the measured one; the whole stated range lies above it.
By their numbers in this assay, from the lowest: compound 3; then compound 2; then compound 1.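

In this assay the aromatic group at this position can be exchanged as a whole, and not only the substituent on a phenyl ring: thiophen-2-yl in place of 2-methylphenyl gives a 3.2-fold lower number from compound 2 to compound 3 (0.51 log units; beyond the scatter) and thiophen-2-yl in place of 2-hydroxyphenyl gives a 22-fold lower number from compound 1 to compound 3 (1.35 log units; beyond the scatter) on the way to the lowest number of the three compounds. A six-membered aromatic ring of carbon only is therefore not needed here for a low number, and the entering group, with 5 heavy atoms against 7 for 2-methylphenyl, shows that a smaller group can go with a lower number in this series. No data at hand bear on why this exchange lowers the number.

The change alters ring size, brings in sulfur and removes the methyl all at once, so the three compounds do not show which of these parts carries the step. Unsubstituted phenyl, furan-2-yl and thiophen-3-yl would separate these parts, and a methyl or a hydroxy group on the thiophene ring would show whether the difference between compound 1 and compound 2 carries over to the five-membered ring.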